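Chain growth on the saturated ring carbon of the core

The compounds below may be only part of what the source reports. "The series", "measured", "known", "first", "only" and "open" are said of these compounds alone.

The shared core carries a sulfonamide-bearing aryl amine and a saturated ring. Compound 1 `CN1CC(=O)N(C)c2cnc(Nc3ccc(S(N)(=O)=O)cc3)nc21` has a hydrogen on the saturated ring carbon, and in an assay on Sf9 cells for inhibition of serine/threonine-protein kinase 4 (Homo sapiens), read by luminescence and ADP-Glo, with a stated time of 1 h, in the presence of a further agent that is not named here (on this read-out lower numbers stand for stronger inhibition and higher numbers for weaker inhibition), compound 1 gives 495 nM. Compound 2 `CC1C(=O)N(C)c2cnc(Nc3ccc(S(N)(=O)=O)cc3)nc2N1C` carries a methyl on that saturated ring carbon; in this assay compound 2 gives 313 nM. Among the compounds with values here, the single step measured so far, a 1.6-fold lower number from compound 1 to compound 2 (0.20 log units; within the scatter), is within the scatter, so compound 2 and compound 1 sit within the usual scatter of each other and neither can be called the more potent on these two numbers.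

Compound 3 `CCC1C(=O)N(C)c2cnc(Nc3ccc(S(N)(=O)=O)cc3)nc2N1C` differs from compound 2 by methyl in place of hydrogen on a saturated chain carbon bound to a saturated ring carbon. Within the data shown here, the only step that bears on it is the first methylation at the same region of the ring, a 1.6-fold lower number from compound 1 to compound 2 (0.20 log units; within the scatter), which stayed within the scatter. With one step to go on, and that one small, the further methyl is expected to give no step beyond the scatter in this assay, a 1.0-fold lower number from compound 2 to compound 3 (0.02 log units; within the scatter). Compound 3 is therefore estimated at 300 nM, with a range from 120 nM to 750 nM in this assay.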

Compound 3, half-maximal inhibitory concentration: 479 nM
For compound 3 the middle estimate is 1.6-fold (0.20 log units) below the measured one; the measured number falls inside the stated range.
By their numbers in this assay, from the lowest: compounds 2, 3 and 1 (each within the scatter of the next).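

Growing the methyl of compound 2 into the ethyl of compound 3 gives a 1.5-fold higher number from compound 2 to compound 3 (0.18 log units; within the scatter) in this assay, and setting ethyl directly in place of the hydrogen of compound 1 gives a 1.0-fold lower number from compound 1 to compound 3 (0.01 log units; within the scatter). Within the data shown here, the earlier pair offered only one small step at this saturated ring carbon; hydrogen, methyl and ethyl now form a short set in which no step leaves the scatter, so no dependence of the number on chain length can be read from compounds 1, 2 and 3, and this position accepts the ethyl without a step that can be distinguished from repeat measurement. No accompanying measurement bears on these numbers, so nothing can be said about what lies behind them.

On these data alone, whether this flat reading holds for a longer chain such as propyl or butyl, or for a branched chain such as isopropyl, stays open. Also open, as far as these compounds go, is whether a chain ending in an amine, a hydroxyl or a carboxylic acid at this ring carbon would give a step beyond the scatter in this assay in either direction.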